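This account rests on a few compounds, and the source may have more. Where it says the series, first, only, none or still open, it means among the compounds named here.

The three measured compounds share one core, seen in compound 1 `CC(=O)Nc1ccc(O)c(C(=O)/C=C/c2ccccc2)c1`. In an ADME assay on MT4 cells (Homo sapiens) for cytotoxicity, read by MTT assay, with a stated time of 4 days (a higher number here means that more compound is tolerated, a lower number that less compound is tolerated), compound 1 gives 49400 nM. On the numbers shown, compound 1 has the largest value, yet the two other compounds sit within the usual scatter of it, so the three cannot be told apart with confidence. Compound 2 `COc1ccc(/C=C/C(=O)c2cc(NC(C)=O)ccc2O)cc1` carries methoxy in place of hydrogen on an aromatic carbon; in this assay compound 2 gives 38700 nM, and the step is a 1.3-fold lower number from compound 1 to compound 2 (0.11 log units; within the scatter). Compound 3 `CC(=O)Nc1ccc(O)c(C(=O)/C=C/c2cccc(F)c2)c1` carries fluoro in place of hydrogen on an aromatic carbon; in this assay compound 3 gives 30100 nM, and the step is a 1.6-fold lower number from compound 1 to compound 3 (0.22 log units; within the scatter).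

Compound 4 `CC(=O)Nc1ccc(O)c(C(=O)/C=C/c2ccc(F)cc2)c1` has not yet been measured in this assay. It differs from compound 1 as follows: fluoro in place of hydrogen on an aromatic carbon. Both measured steps bear on this change, since each places a single small group on the same ring of compound 1, and neither moved the number beyond the scatter. The step from compound 1 to compound 4 is therefore expected to be a 1.3-fold lower number from compound 1 to compound 4 (0.11 log units; within the scatter), that is, nothing beyond the scatter. For compound 4 the estimated value in this assay is 38000 nM, with a likely range from 19000 nM to 76000 nM.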

Compound 4, half-maximal cytotoxic concentration: 41100 nM
Compound 4: middle estimate off by 1.1-fold (0.03 log units), on the low side; measured number inside the range.
By their numbers in this assay, from the lowest: compounds 3, 2, 4 and 1 (each within the scatter of the next).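

Fluoro on the aromatic carbon para to a large group gives, in this assay, a 1.2-fold lower number from compound 1 to compound 4 (0.08 log units; within the scatter), so this third single-group change on the ring, like the two before it, stays inside the scatter. For the compounds shown here, compound 3 and compound 4 allow the first direct comparison of one group at two places, and the change to 4-fluorophenyl from 3-fluorophenyl gives a 1.4-fold higher number from compound 3 to compound 4 (0.14 log units; within the scatter), so on these numbers the place of the fluoro makes no readable difference. Compound 2 and compound 4 add a comparison of two groups with each other, and fluoro in place of methoxy gives a 1.1-fold higher number from compound 2 to compound 4 (0.03 log units; within the scatter), so these two groups cannot be told apart here either.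

No other measurement is available to explain why these numbers lie so close together.
From the compounds shown here alone, it remains open whether a different kind of group on this ring, such as an amine or a carboxylic acid, would take the number beyond the scatter, and whether a change elsewhere on the shared core, such as a longer chain on the amide, would do so.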